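Swapping the oxolanyl group for a methylcyclopropyl group

A few compounds are considered here, and "the series" means these few. Any claim that something is new, unique, unknown or untested is made for them only; others in the source may bear on it.

Measured so far:
Compound 1 `Fc1ccc(-c2nc3cnc(Nc4ccc(C(F)(F)F)cn4)cc3[nH]2)cc1F`: 89%
Compound 2 `FC(F)(F)c1ccc(Nc2cc3[nH]c(C4CCOC4)nc3cn2)nc1`: 67%

In an ADME assay on microsomes from liver (Mus musculus) for metabolic stability, read by LC-MS, with a stated time of 30 min, tested at 0.1 uM (a lower number here means that less of the compound is left, a higher number that more of the compound is left), compound 2 stands lowest of the two numbers shown, since the step of a number 22 percentage points lower from compound 1 to compound 2 (beyond the scatter) was beyond the scatter. Compound 3 `CC1(c2nc3cnc(Nc4ccc(C(F)(F)F)cn4)cc3[nH]2)CC1` differs from compound 2 by 1-methylcyclopropyl in place of oxolan-3-yl on an aromatic carbon. Among the compounds with values here, the only measured step at this position is a number 22 percentage points lower from compound 1 to compound 2 (beyond the scatter), and it does not involve 1-methylcyclopropyl, so it gives no direct guide to the direction. A step of a number 3 percentage points higher from compound 2 to compound 3 (within the scatter) is therefore expected, within the scatter. For compound 3 a value of 70% is estimated, within a range of 50% to 88%.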

Compound 3, percent of the compound remaining: 41%
The estimate for compound 3 lay 29 percentage points above the measured number; the measured number lies below the stated range.
By their numbers in this assay, from the lowest: compound 3; then compound 2; then compound 1.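

In this assay, 1-methylcyclopropyl in place of oxolan-3-yl gives a number 26 percentage points lower from compound 2 to compound 3 (beyond the scatter), so two small non-aromatic rings on this carbon do not behave alike. Set against the 3,4-difluorophenyl group, the same change gives a number 48 percentage points lower from compound 1 to compound 3 (beyond the scatter), the largest step among these compounds. No measurement here explains either step.

On these data alone, whether the ring oxygen or the ring size separates compound 2 from compound 3 stays open. So does the outcome with a pyridine ring, a morpholine or a tert-butyl group at this position.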